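A Second Methoxy Group on the Shared Core

The source may report more compounds than this note shows. Statements on the series, on what has been measured and on what is new or still open speak of the compounds shown alone.

Of the compounds shown here, two have so far been measured in a functional assay on the whole organism (strain Wistar) for inhibition, with Rattus norvegicus as the target, read by paw edema, with stated times of 30 min and 5 h, at a dose of 0.05 mmol/kg by the oral route; a lower number here means less inhibition, a higher number more inhibition at the dose given (going by the name of the read-out).

Compound 1, `COc1ccc(C2=NN(c3ccc(S(C)(=O)=O)cc3)C(=O)CC2)cc1`, gives 68.4%.
Compound 2, `CCc1ccc(C2=NN(c3ccc(S(C)(=O)=O)cc3)C(=O)CC2)cc1`, gives 65.7%.

Compound 1 has the higher of the two numbers in this assay, but the gap to compound 2 is small: the step of a number 2.7 percentage points lower from compound 1 to compound 2 (within the scatter) lies within the scatter, so the two cannot be told apart. That one step exchanges one group for another in a single place.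

Compound 3, `COc1ccc(C2=NN(c3ccc(S(C)(=O)=O)cc3)C(=O)CC2)cc1OC`, is not yet measured. It differs from compound 1 in one place: methoxy in place of hydrogen on an aromatic carbon. Here only a hydrogen atom leaves, and a methoxy group enters. Going by the values given here, no measured step matches this change; the only step known, from compound 1 to compound 2, swaps one group for another rather than adding one, and is itself within the scatter. These numbers therefore give no ground for expecting a step in this assay beyond the scatter in either direction, though the lack of a comparable step calls for a wide margin. Compound 3 is estimated to give 62%, with a range from 45% to 78%, which corresponds to an expected step of a number 6.4 percentage points lower from compound 1 to compound 3 (within the scatter).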

Compound 3, a percentage reported as inhibition, in the whole organism at one dose (the size of the read-out at that dose, not a potency): 82.4%
Compound 3: the middle estimate sits 20.4 percentage points below what was measured; measured number above the stated range.
By their numbers in this assay, from the lowest: compounds 2 and 1 (each within the scatter of the next); then compound 3.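

Adding a methoxy group on the aromatic carbon ortho to a methoxy group gives the only change here that moves the number in this assay beyond the scatter, with a number 14 percentage points higher from compound 1 to compound 3 (beyond the scatter) on the shared core. Putting ethyl in place of methoxy gave a number 2.7 percentage points lower from compound 1 to compound 2 (within the scatter) and so could not show that the number responds to changes on this ring, whereas this added group shows that it can. The data at hand offer nothing that explains why this addition goes with more inhibition of the paw edema.

The compounds shown leave open whether the gain belongs to methoxy itself or would also appear with another group on the same carbon, such as a hydroxyl, an ethoxy or a fluorine, or with a longer chain ending in an amine. They also leave open how compound 3 would compare with compound 1 at other doses, since a single dose gives the size of the effect and not a potency.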